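The source may report more compounds than this note shows. Statements on the series, on what has been measured and on what is new or still open speak of the compounds shown alone.

In a functional assay on SR cells (Homo sapiens) for inhibition, read by sulforhodamine B assay, with a stated time of 48 h (on this read-out lower numbers stand for stronger inhibition of growth and higher numbers for weaker inhibition of growth), three compounds have been examined. Compound 1 `COc1ccc(-c2cc(/C=C/C(=O)c3ccc(OC)c(OC)c3)[nH]n2)cc1` gives 3740 nM, compound 3 `COc1ccc(-c2cc(/C=C/C(=O)c3ccc(N)cc3)[nH]n2)cc1` gives 6090 nM, and compound 2 `COc1cc(-c2cc(/C=C/C(=O)c3ccc(Cl)c(Cl)c3)[nH]n2)cc(OC)c1OC` gives 13500 nM, the highest number of the three, with the gaps to the other two both beyond the usual scatter. Compound 4 `COc1ccc(C(=O)/C=C/c2cc(-c3cc(OC)c(OC)c(OC)c3)n[nH]2)cc1OC` shares the core of compound 2 and differs from it in one place: 3,4-dimethoxyphenyl in place of 3,4-dichlorophenyl on a carbonyl carbon. For the measured compounds named here, no pair of measured compounds traces this change on its own, so the expected step from compound 2 to compound 4 rests on the whole picture, and a step downward beyond the scatter is expected, a 2.7-fold lower number from compound 2 to compound 4 (0.43 log units; beyond the scatter), because compound 1, which carries the same 3,4-dimethoxyphenyl on its carbonyl carbon, gives 3740 nM. For compound 4 the estimated value is 5000 nM, within a range of 2000 nM to 13000 nM.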

Compound 4, concentration for total growth inhibition: > 100000 nM
Compound 4 gave a limit, no number (the forecaster's own chance of this, stated with the estimate: 5%); at least 20-fold (1.30 log units) between middle value and limit.
By their numbers in this assay, from the lowest: compounds 1 and 3 (each within the scatter of the next); then compound 2. At a limit, above all of these: compound 4.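

For the compounds shown here, this is the only single change seen on the carbonyl carbon, and it shows that the group there matters on the core of compound 2: in this assay, 3,4-dimethoxyphenyl in place of 3,4-dichlorophenyl gives an at least 7.4-fold higher number from compound 2 to compound 4 (0.86 log units; beyond the scatter). Compound 4 gives > 100000 nM, which is a limit of the assay and not a number, so the step has a lower bound but no known full size. On these data alone, with one pair, it remains open whether the loss of growth inhibition would also appear on another core, and how a phenyl ring carrying an amine or a carboxylic acid would behave on this carbonyl carbon.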